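The source may hold more compounds than are shown below. What is called first, only, known or untested is meant among the compounds shown, and "the series" means these compounds.

Measured in an ADME assay on Vero cells (Chlorocebus sabaeus) for cytotoxicity, read by neutral red uptake, tested at 1575 ug/mL; a lower number here means a stronger effect, a higher number a weaker effect of the compound at the concentration tested:

- compound 1 `COc1ccc(C2SCC(=O)N2CCN2CCCCC2)cc1` gives 11%
- compound 2 `O=C1CSC(c2ccc(F)cc2)N1CCN1CCCCC1` gives 14%
- compound 3 `O=C1CSC(c2cccc(F)c2)N1CCN1CCCCC1` gives 17%

All three numbers lie close together, so none of the compounds can be set apart from the others on this read-out.

Compound 4 `COc1cccc(C2SCC(=O)N2CCN2CCCCC2)c1` has not yet been measured. It differs from compound 3 by methoxy in place of fluoro on an aromatic carbon. The same kind of change has already been made once, from compound 2 to compound 1, where it is methoxy in place of fluoro on an aromatic carbon and gave a step of a number 3 percentage points lower from compound 2 to compound 1 (within the scatter). The two places are not identical: in compound 1 the methoxy sits para to a large group, in compound 4 it sits meta to a large group, so this is the same kind of change rather than the same change. The two cores themselves differ by 3-fluorophenyl in place of 4-fluorophenyl on a saturated ring carbon, a change that gave a step of a number 3 percentage points higher from compound 2 to compound 3 (within the scatter).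

Because the earlier step of a number 3 percentage points lower from compound 2 to compound 1 (within the scatter) stayed within the scatter, the step from compound 3 to compound 4 is expected to be small as well, about a number 3 percentage points lower from compound 3 to compound 4 (within the scatter). On that basis compound 4 is estimated at 14% in this assay, with a likely range from 5% to 25%.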

Compound 4, a percentage reported as activity, at one concentration (the size of the read-out at that concentration, not a potency): 11%
Estimate against measurement, compound 4: 3 percentage points above; measured number inside the range.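

In this assay, methoxy in place of fluoro on the aromatic ring gives a step of a number 6 percentage points lower from compound 3 to compound 4 (within the scatter). Set beside the earlier case, the change looks the same on both cores: the same change on two cores in this assay, a number 3 percentage points lower (within the scatter) from compound 2 to compound 1 and a number 6 percentage points lower (within the scatter) from compound 3 to compound 4, 3 percentage points apart, within the scatter of two such steps. This shows that, on these two cores, the swap carries over as a step too small to tell from repeat-to-repeat variation, but it does not show that methoxy and fluoro truly differ in this read-out, nor that the same would hold on any further core, as two pairs are a thin basis for a rule.

The compounds shown carry only fluoro or methoxy on the aromatic ring, so it remains open what an amine, a carboxylic acid or a longer chain such as ethoxy would do on the same aromatic carbon. Also open, from the compounds shown here alone, is whether a change elsewhere in the shared core would move the number beyond the scatter.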